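The compounds below may be only part of what the source reports. "The series", "measured", "known", "first", "only" and "open" are said of these compounds alone.

Measured so far in a functional assay on PC-3 cells (Homo sapiens) for antiproliferative activity, read by MTT assay, with a stated time of 48 h; a higher number here means a weaker inhibitor, a lower number a stronger inhibitor:

compound 1 `Cc1ccc2nc(Nc3nc(Nc4ccc(S(C)(=O)=O)cc4)ncc3F)sc2c1`: compound 1 gives > 50000 nM in this assay, a limit of the assay and not a number.
compound 2 `CS(=O)(=O)c1ccc(Nc2nccc(Nc3nc4ccc(F)cc4s3)n2)cc1`: compound 2 gives 1940 nM in this assay.
compound 3 `CS(=O)(=O)c1ccc(Nc2nccc(Nc3nc4ccccc4s3)n2)cc1`: compound 3 gives 1710 nM in this assay.

Compound 3 holds the lower of the two numbers shown, but it is separated from compound 2 only by a 1.1-fold lower number from compound 2 to compound 3 (0.05 log units; within the scatter), which is within the scatter, so the two cannot be told apart on these data.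

Compound 4 `Cc1ccc2nc(Nc3ccnc(Nc4ccc(S(C)(=O)=O)cc4)n3)sc2c1` differs from compound 3 by methyl in place of hydrogen on an aromatic carbon. Among the measured compounds shown here, no measured step covers this change: the single measured step, a 1.1-fold lower number from compound 2 to compound 3 (0.05 log units; within the scatter), concerns a fluoro on the same fused ring and is within the scatter. Compound 1 also carries this methyl but differs from compound 4 elsewhere. In this assay compound 1 gives > 50000 nM, a limit of the assay and not a number.

For the measured compounds named here, with no direct precedent, the methyl is expected to move the number little; the estimated step is a 1.5-fold higher number from compound 3 to compound 4 (0.16 log units; within the scatter), with wide uncertainty. Compound 4 is therefore estimated at 2500 nM in this assay, with a range of 900 nM to 9000 nM.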

Compound 4, half-maximal inhibitory concentration: > 50000 nM
Compound 4: no number, only a limit (the forecaster's own chance of this, stated with the estimate: 12%); middle value at least 20-fold (1.30 log units) away from the limit.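

Compound 4 gives > 50000 nM in this assay, a limit of the assay and not a number. This aromatic carbon had looked insensitive to its substituent, with a 1.1-fold lower number from compound 2 to compound 3 (0.05 log units; within the scatter), but methyl changes that picture, with an at least 29-fold higher number from compound 3 to compound 4 (1.46 log units; beyond the scatter) and an at least 25-fold higher number from compound 2 to compound 4 (1.41 log units; beyond the scatter), so the position does not accept every small group alike. Compound 1 and compound 4 both stand at a limit, so the step between them cannot be read: the limit of > 50000 nM in this assay, at which 2 of the 4 values shown sit.

Going by these compounds, whether the loss is particular to methyl stays open, and a chloro, a methoxy or an amine on this same aromatic carbon would test that. Also open, on these data alone, are the true size of the loss, as compound 4 has no number, and whether the fluoro of compound 1 has any effect of its own without the methyl.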